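Trifluoromethyl for Methyl on the Amide Aryl Ring

The source may hold more compounds than are shown below. What is called first, only, known or untested is meant among the compounds shown, and "the series" means these compounds.

Of the compounds shown here, three built on one shared core have been measured in an assay on HEK293 cells for displacement of a labelled ligand from metabotropic glutamate receptor 5 (Rattus norvegicus); on this read-out higher numbers stand for weaker inhibition and lower numbers for stronger inhibition. Compound 1 `O=C(Nc1cc(-c2ccccc2)nn1-c1ccccc1)c1cccc(C(F)(F)F)c1` gives 1650 nM, compound 2 `O=C(Nc1cc(-c2ccccc2)nn1-c1ccccc1)c1cccc([N+](=O)[O-])c1` gives 2220 nM, and compound 3 `Cc1ccc(C(=O)Nc2cc(-c3ccccc3)nn2-c2ccccc2)cc1` gives 780 nM, the lowest of the three numbers. Compound 4 `O=C(Nc1cc(-c2ccccc2)nn1-c1ccccc1)c1ccc(C(F)(F)F)cc1` differs from compound 3 by trifluoromethyl in place of methyl on an aromatic carbon. Going by the values given here, no measured step swaps these two groups at the same place, so the nearest guides are a 2.1-fold lower number from compound 1 to compound 3 (0.33 log units; beyond the scatter) and a 2.8-fold lower number from compound 2 to compound 3 (0.45 log units; beyond the scatter), both moving from a substituted phenyl on the carbonyl carbon to 4-methylphenyl. Since compound 4 partly reverses that move by bringing trifluoromethyl back, a modest rise in this assay is expected, as a 1.7-fold higher number from compound 3 to compound 4 (0.22 log units; within the scatter). Compound 4 is therefore estimated at 1300 nM, with a range from 500 nM to 3200 nM.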

Compound 4, inhibition constant: 990 nM
Estimate against measurement, compound 4: 1.3-fold (0.12 log units) above; measured number inside the range.
By their numbers in this assay, from the lowest: compounds 3, 4, 1 and 2 (each within the scatter of the next, the first and the last beyond it).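

Going by these compounds alone, putting trifluoromethyl in place of methyl on the aromatic carbon para to a large group gives a 1.3-fold higher number from compound 3 to compound 4 (0.10 log units; within the scatter) and is the first direct comparison of these two groups at one place, which they do not separate. The step of a 1.7-fold lower number from compound 1 to compound 4 (0.22 log units; within the scatter) is also within the scatter, so these compounds do not resolve where trifluoromethyl sits on the ring, while a 2.2-fold lower number from compound 2 to compound 4 (0.35 log units; beyond the scatter) is beyond it. No supporting data explain these results. From the compounds shown here alone, whether an amine, a carboxylic acid or a longer chain at this place would give a similar number remains open, as does whether methyl and trifluoromethyl would also match elsewhere on the shared core.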